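A benzyl in place of methyl on compound 4

The source may hold more compounds than are shown below. What is called first, only, known or untested is meant among the compounds shown, and "the series" means these compounds.

Three compounds have numbers or limits so far. In a functional assay on U-118-MG cells (Homo sapiens) for cytotoxicity, read by MTT assay, with a stated time of 48 h (a higher number here means a weaker inhibitor, a lower number a stronger inhibitor), compound 1 (`CCOC(=O)C[n+]1cccc2cc(O)ccc21`) reads > 200000 nM and that entry is a limit of the assay, not a number. In this assay compound 2 (`O=C(O[C@H]1C[C@H](n2cc(F)c(=O)[nH]c2=O)O[C@@H]1COP(=O)(O)Oc1ccc2ncccc2c1)c1ccccc1`) gives 790 nM as its half-maximal inhibitory concentration. Compound 3 (`C[n+]1cccc(OP(=O)([O-])OC[C@H]2O[C@@H](n3cc(F)c(=O)[nH]c3=O)C[C@@H]2OC(=O)c2ccccc2)c1`) gives 3150 nM and so holds the higher of the two actual numbers, with compound 2 lying lower by a gap beyond the usual scatter.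

Compound 4 (`O=C(O[C@H]1C[C@H](n2cc(F)c(=O)[nH]c2=O)O[C@@H]1COP(=O)([O-])Oc1ccc[n+](Cc2ccccc2)c1)c1ccccc1`) has not yet been measured. It departs from compound 3 by a single change: phenyl in place of hydrogen on a saturated chain carbon bound to an aromatic nitrogen with phenyl in place of hydrogen on a saturated chain carbon bound to an aromatic nitrogen, which can also be read as methyl to benzyl.

Going by the values given here, no measured pair isolates this change, so any forecast in this assay stays loose. A modest move towards a lower number is expected, perhaps not beyond the scatter, since compound 2 at 790 nM shows that numbers under that of compound 3 occur among these compounds. The expected change is a 1.6-fold lower number from compound 3 to compound 4 (0.20 log units; within the scatter) and it remains only an estimate. Compound 4 is estimated at 2000 nM with an expected range from 600 nM to 7000 nM until the measurement arrives.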

Compound 4, half-maximal inhibitory concentration: 1470 nM
Estimate against measurement, compound 4: 1.4-fold (0.13 log units) above; low and high end bracket the measured number.
By their numbers in this assay, from the lowest: compounds 2 and 4 (each within the scatter of the next); then compound 3. At a limit, above all of these: compound 1.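

In this assay, going by these compounds alone, the change from methyl to benzyl gives the first step that can be read at this position, on a saturated chain carbon bound to an aromatic nitrogen, with a 2.1-fold lower number from compound 3 to compound 4 (0.33 log units; beyond the scatter). The earlier compounds shown here offered no pair differing in one place, so they could not show that phenyl in place of hydrogen here goes with a lower number, and this single modest step now does so for this one pair. Nothing in the data shown explains the step, as no measured property bears on it.

One step cannot separate the contribution of the phenyl ring from that of a larger group on this carbon in general, and an ethyl group, a longer chain, or a benzyl carrying an amine or a carboxylic acid on its ring would each test this differently. On these data alone, whether the same change would give a similar step on the phosphate-linked quinoline-type partner of compound 2, or in any other cell line, also remains open.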